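The compounds below may be only part of what the source reports. "The series", "measured", "known", "first", "only" and "open" are said of these compounds alone.

Compound 1 `Cc1ccccc1NNC(=O)c1ccccc1NS(=O)(=O)c1cnc(O)nc1O` was examined in a functional assay on SGC-7901 cells (Homo sapiens) for antiproliferative activity, read by MTT assay, with a stated time of 24 h; on this read-out higher numbers stand for weaker inhibition and lower numbers for stronger inhibition. In this assay compound 1 gives > 20000 nM, which is a limit of the assay and not a measured number. Going by the values given here, the only other compound with a value here is compound 2 `O=C(NNC(=O)c1ccccc1F)c1cccc(NS(=O)(=O)c2cnc(O)nc2O)c1`. In this assay compound 2 gives > 20000 nM, again a limit of the assay rather than a number. Among the compounds with values here, both results therefore sit at the limit of > 20000 nM in this assay, at which 2 of the 2 values shown sit, so compound 1 stands level with the one further value shown, and no step between measured compounds is available to draw on. Compound 3 `O=C(NNC(=O)c1ccccc1NS(=O)(=O)c1cnc(O)nc1O)c1cccc(Cl)c1` has not yet been measured in this assay. Compared with compound 1 it changes in a single place: (3-chlorophenyl)carbonyl in place of 2-methylphenyl on an amine nitrogen, which read one bond further out is ((3-chlorophenyl)carbonyl)amino in place of (2-methylphenyl)amino. With nothing measured to anchor the direction, the step from compound 1 to compound 3 is expected to be a step that the limit leaves unreadable from compound 1 to compound 3, that is, no movement beyond the usual scatter. Compound 3 is accordingly estimated at 25000 nM, within a range from 8000 nM to 60000 nM, and the assay is likely to report only a limit again.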

Compound 3, half-maximal inhibitory concentration: 1820 nM
For compound 3 the middle estimate is 14-fold (1.14 log units) above the measured one; the measured number lies below the stated range.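

In this assay, the substituent on the amine nitrogen whose other neighbour is an amide-type nitrogen proves able to change the read-out, which the two earlier limits could not show. Setting (3-chlorophenyl)carbonyl in place of 2-methylphenyl at this position gives an at least 10-fold lower number from compound 1 to compound 3 (1.04 log units; beyond the scatter), and compound 3 gives 1820 nM, a measured number rather than a limit. The full size of this step cannot be read because the result for compound 1 is a limit of the assay and not a number: the limit of > 20000 nM in this assay, at which 2 of the 3 values shown sit.

The change brings in a carbonyl and a chlorine and removes a methyl-bearing aryl group in one step, so the compounds shown do not tell which of these parts accounts for the lower number. From the compounds shown here alone, it also remains open whether a plain phenylcarbonyl group without the chlorine, a (3-methoxyphenyl)carbonyl group or a small acetyl group at the same nitrogen would give a measured value like that of compound 3 or return to the limit.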